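Ester Ring Swap and Stability in Mouse Hepatocytes

The compounds below may be only part of what the source reports. "The series", "measured", "known", "first", "only" and "open" are said of these compounds alone.

Three compounds share one core and differ only in the ring attached to a carbonyl carbon of an ester. Compound 1 `O=C(OC1CCC(CN2CCN(c3cc(=O)c4cc(C(F)(F)F)cc([N+](=O)[O-])c4s3)CC2)CC1)c1cccs1` carries a thiophen-2-yl group, compound 2 `COc1ccc(C(=O)OC2CCC(CN3CCN(c4cc(=O)c5cc(C(F)(F)F)cc([N+](=O)[O-])c5s4)CC3)CC2)cc1` a 4-methoxyphenyl group, and compound 3 `O=C(OC1CCC(CN2CCN(c3cc(=O)c4cc(C(F)(F)F)cc([N+](=O)[O-])c4s3)CC2)CC1)c1ccncc1` a pyridin-4-yl group. In an ADME assay on cells (Hepatocyte, Mus musculus) for metabolic stability, with a stated time of 30 min (on this read-out lower numbers stand for a less stable compound and higher numbers for a more stable compound), compound 1 gives 1.8%, compound 2 gives 31%, and compound 3 gives 1.4%. Compound 3 thus sits at the bottom of the three numbers, with compound 1 close by and compound 2 well apart: a number 0.4 percentage points lower from compound 1 to compound 3 (within the scatter), whereas a number 29.6 percentage points lower from compound 2 to compound 3 (beyond the scatter).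

Going by the values given here, compound 4 `O=C(OC1CCC(CN2CCN(c3cc(=O)c4cc(C(F)(F)F)cc([N+](=O)[O-])c4s3)CC2)CC1)c1ccc(C(F)(F)F)cc1` has not yet been measured. 4-(trifluoromethyl)phenyl in place of pyridin-4-yl on a carbonyl carbon No measured step makes this exact exchange. The nearest guides are the two steps that involve the 4-methoxyphenyl ester. One is a number 29.2 percentage points higher from compound 1 to compound 2 (beyond the scatter). The other is the step just mentioned from compound 2 to compound 3. In both, the ester with a six-membered ring of carbon only sat well higher than the esters with a ring containing a hetero atom. A rise beyond the scatter is therefore expected, though its size is uncertain, since a trifluoromethyl group is not a methoxy group. The expected step is a number 13.6 percentage points higher from compound 3 to compound 4 (beyond the scatter). Compound 4 is estimated at 15%, with a range from 2% to 40%.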

Compound 4, percent of the compound remaining: 28.8%
Beside the measured number, compound 4's estimate is 13.8 percentage points below it, within the range that was stated.
By their numbers in this assay, from the lowest: compounds 3 and 1 (each within the scatter of the next); then compounds 4 and 2 (each within the scatter of the next).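

In this assay there is now a second ring of carbon only on the carbonyl carbon, and it repeats what compound 2 showed alone: a number 27.4 percentage points higher from compound 3 to compound 4 (beyond the scatter) and a number 27 percentage points higher from compound 1 to compound 4 (beyond the scatter), so among these four compounds both carbon-only rings sit well apart from both rings with a hetero atom. The substituent on that ring has a different reading: trifluoromethyl in place of methoxy on an aromatic carbon gives a number 2.2 percentage points lower from compound 2 to compound 4 (within the scatter), so two quite different groups cannot be told apart on this read-out. Going by these compounds alone, nothing given here explains why the ring exchange moves the number so far.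

Both carbon-only rings carry a substituent, so the compounds shown leave open whether a plain phenyl ring with only hydrogens would stay with compound 2 and compound 4 or fall to the level of compound 1 and compound 3. They also leave open how far the tolerance for substituents extends, for example to an amine, a carboxylic acid or a longer alkyl chain in place of trifluoromethyl.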